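This account rests on a few compounds, and the source may have more. Where it says the series, first, only, none or still open, it means among the compounds named here.

Within the data shown here, compound 3 `COc1c(C2CCN(c3ccn4c(CC5CC5)nnc4c3Cl)CC2)ccc(F)c1F` gives 26 nM in a functional assay on CHO cells for agonist activity at metabotropic glutamate receptor 2 (Homo sapiens), read by scintillation counting and GTPgammaS binding, with a stated time of 30 min (on this read-out higher numbers stand for an effect only at larger amounts of compound and lower numbers for an effect already at smaller amounts), the second highest of the three numbers measured so far; its nearest neighbour is compound 1 `COc1ccccc1C1CCN(c2ccn3c(CC4CC4)nnc3c2Cl)CC1`, which gives 20 nM, with the step of a 1.3-fold higher number from compound 1 to compound 3 (0.11 log units; within the scatter) within the scatter. Compound 2 `COc1c(F)cccc1C1CCN(c2ccn3c(CC4CC4)nnc3c2Cl)CC1` gives 37 nM. Compound 4 `COc1cc(F)cc(F)c1C1CCN(c2ccn3c(CC4CC4)nnc3c2Cl)CC1` differs from compound 3 only in how the same atoms are joined: 2,4-difluoro-6-methoxyphenyl in place of 3,4-difluoro-2-methoxyphenyl on a saturated ring carbon. The measured steps that bear on placing fluoro on this ring are both small, namely a 1.9-fold higher number from compound 1 to compound 2 (0.27 log units; within the scatter) and a 1.4-fold lower number from compound 2 to compound 3 (0.15 log units; within the scatter), and neither leaves the scatter. No step beyond the scatter is therefore expected in this assay for this rearrangement. Compound 4 is estimated at 30 nM, within 10 nM to 90 nM, which means an expected step of a 1.2-fold higher number from compound 3 to compound 4 (0.06 log units; within the scatter).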

Compound 4, half-maximal effective concentration: 6.9 nM
Estimate against measurement, compound 4: 4.3-fold (0.64 log units) above; measured number below the stated range.
By their numbers in this assay, from the lowest: compound 4; then compounds 1, 3 and 2 (each within the scatter of the next).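

In this assay, among these compounds, the earlier compounds showed only steps within the scatter, whereas this rearrangement shows that where the two fluoro groups and the methoxy sit on the aromatic ring matters: the same atoms, joined as 2,4-difluoro-6-methoxyphenyl, give a 3.8-fold lower number from compound 3 to compound 4 (0.58 log units; beyond the scatter). Among the compounds shown here, the same group also gives a 5.4-fold lower number from compound 2 to compound 4 (0.73 log units; beyond the scatter) and a 2.9-fold lower number from compound 1 to compound 4 (0.46 log units; beyond the scatter), so only the steps to compound 4 leave the scatter. No measurement at hand accounts for this. Going by these compounds, it remains open which of the two fluoro groups of compound 4 carries the step, and whether an ethoxy or an amine in place of the methoxy would keep it.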